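The source may report more compounds than this note shows. Statements on the series, on what has been measured and on what is new or still open speak of the compounds shown alone.

Three compounds in a cell-based test for slowing the growth of liver-derived cancer cells open the story. In a functional assay on HepG2 cells (Homo sapiens) for antiproliferative activity, read by MTT assay, with a stated time of 72 h (on this read-out higher numbers stand for weaker inhibition and lower numbers for stronger inhibition), compound 1 `O=c1nc2oc(CCCCl)c(C#CCCCCCl)c2cn1Cc1cn(-c2ccc(F)cc2)nn1` gives 36900 nM, compound 2 `O=c1nc2oc(CCCCl)cc2cn1Cc1cn(-c2ccc(F)cc2)nn1` gives 14600 nM, and compound 3 `O=c1c(I)cn(Cc2cn(Cc3ccccc3)nn2)c(=O)n1Cc1cn(Cc2ccccc2)nn1` gives 5770 nM. Compound 2 therefore stands second highest of the three numbers, with compound 1 above it and compound 3 below it, each beyond the scatter.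

Among the measured compounds shown here, only one pair differs in a single place: a 2.5-fold lower number from compound 1 to compound 2 (0.40 log units; beyond the scatter), where hydrogen replaces 6-chlorohex-1-yn-1-yl on an aromatic carbon.

Compound 4 `O=c1nc2oc(CCCCl)cc2cn1Cc1cn(Cc2ccccc2)nn1` is built from compound 2 by one change: benzyl in place of 4-fluorophenyl on an aromatic nitrogen. For the measured compounds named here, no measured step concerns this spot, since compound 3 carries benzyl groups on its five-membered aromatic rings with 3 nitrogen but on a different core, so its value cannot be read as a step from compound 2. With nothing bearing on the swap, the expected change is small, a 1.0-fold lower number from compound 2 to compound 4 (0.02 log units; within the scatter), and not beyond the scatter. Compound 4 is thus estimated at 14000 nM, within 5000 nM to 40000 nM.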

Compound 4, half-maximal inhibitory concentration: 27600 nM
Compound 4: middle estimate off by 2.0-fold (0.29 log units), on the low side, and the stated range covers the measured number.
By their numbers in this assay, from the lowest: compound 3; then compounds 2, 4 and 1 (each within the scatter of the next, the first and the last beyond it).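

In this assay, among the compounds shown here, benzyl in place of 4-fluorophenyl on the aromatic nitrogen of the five-membered aromatic ring with 3 nitrogen gives a 1.9-fold higher number from compound 2 to compound 4 (0.28 log units; within the scatter) and provides the first direct reading at this position. The two groups have the same number of heavy atoms and each holds one six-membered aromatic ring of carbon only, and on this core the assay does not separate them. No supporting measurement explains this result.

On these data alone, it remains open whether a plain phenyl, a longer chain or a phenyl ring carrying a carboxylic acid at this nitrogen would shift the number beyond the scatter. As far as these compounds go, whether the same swap reads alike on a different core also remains open.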